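The source may report more compounds than this note shows. Statements on the series, on what has been measured and on what is new or still open speak of the compounds shown alone.

Compound 1 `O=C1CCC(/C=C/c2ccc(-c3ccccc3)cc2)=NN1` gives 24.6 umol/kg in a functional assay on the whole organism for inhibition, with Rattus norvegicus as the target, read by paw edema, with a stated time of 4 h (on this read-out higher numbers stand for an effect only at larger amounts of compound and lower numbers for an effect already at smaller amounts), the lowest of the two numbers available, with its nearest neighbour compound 2 `O=C1CCC(/C=C/c2ccc(Oc3ccccc3)cc2)=NN1` at 28.8 umol/kg in this assay, so the two lie within the scatter; the step from compound 1 to compound 2 a 1.2-fold higher number from compound 1 to compound 2 (0.07 log units; within the scatter) replaces phenyl with phenoxy on an aromatic carbon. Compound 3 `CN1N=C(/C=C/c2ccc3c(c2)OCCO3)CCC1=O` carries a methyl on the ring nitrogen, but in this assay compound 3 is recorded as "not determined" (no result reported), so it offers no number. Compound 4 `O=C1CCC(/C=C/c2ccc(-c3ccccc3)cc2)=NN1c1ccccc1` differs from compound 1 by phenyl in place of hydrogen on an amide-type nitrogen in a ring. Going by the values given here, no measured step touches this ring nitrogen, and the one step known lies within the scatter, so no change beyond the scatter is expected from compound 1 to compound 4 a 1.2-fold higher number from compound 1 to compound 4 (0.09 log units; within the scatter). Compound 4 is therefore estimated at 30 umol/kg, within 12 umol/kg to 75 umol/kg.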

Compound 4, dose for half-maximal effect: 38.6 umol/kg
For compound 4 the middle estimate is 1.3-fold (0.11 log units) below the measured one; low and high end bracket the measured number.
By their numbers in this assay, from the lowest: compounds 1, 2 and 4 (each within the scatter of the next).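

In this assay, going by these compounds alone, the first measured step at this amide-type nitrogen in a ring, phenyl in place of hydrogen, gives a 1.6-fold higher number from compound 1 to compound 4 (0.20 log units; within the scatter). The position therefore takes a whole six-membered aromatic ring of carbon only without a change beyond the scatter. Nothing available explains this result.

The compounds shown leave open whether an amine or a carboxylic acid carried on a longer chain at this nitrogen would also stay within the scatter. They also leave open whether phenyl at this nitrogen would give the same result on the core of compound 2.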